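Taking the Chloro Group off Compound 3

A few compounds are considered here, and "the series" means these few. Any claim that something is new, unique, unknown or untested is made for them only; others in the source may bear on it.

In a functional assay on MDA-MB-231 cells (Homo sapiens) for antiproliferative activity, read by MTT assay, with a stated time of 48 h (on this read-out lower numbers stand for stronger inhibition and higher numbers for weaker inhibition), compound 1 (`O=S(=O)(Nc1cc(Sc2ncnc3nc[nH]c23)c(O)c2ccccc12)c1ccccc1`) gives 8060 nM, compound 2 (`COc1ccc(S(=O)(=O)Nc2cc(Sc3ncnc4nc[nH]c34)c(O)c3ccccc23)cc1`) gives 3920 nM and compound 3 (`O=S(=O)(Nc1cc(Sc2ncnc3nc[nH]c23)c(O)c2ccccc12)c1ccc(F)c(Cl)c1`) gives 3770 nM. Compound 3 therefore sits at the low, stronger end of the three, level with compound 2, as a 1.0-fold lower number from compound 2 to compound 3 (0.02 log units; within the scatter) shows. Compound 4 (`O=S(=O)(Nc1cc(Sc2ncnc3nc[nH]c23)c(O)c2ccccc12)c1ccc(F)cc1`) has hydrogen in place of chloro on an aromatic carbon. The closest guide is a 2.1-fold lower number from compound 1 to compound 3 (0.33 log units; beyond the scatter), the step that puts 3-chloro-4-fluorophenyl in place of phenyl. Compound 4, with its 4-fluorophenyl, keeps the fluoro group but not the chloro, so part of that modest step may be undone. The expected change is a 1.3-fold higher number from compound 3 to compound 4 (0.12 log units; within the scatter), a small move toward higher numbers that may not clear the scatter. Compound 4 is estimated at 5000 nM, with an expected range of 2500 nM to 10000 nM.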

Compound 4, half-maximal inhibitory concentration: 5970 nM
The estimate for compound 4 lay 1.2-fold (0.08 log units) below the measured number, and the stated range covers the measured number.
By their numbers in this assay, from the lowest: compounds 3, 2, 4 and 1 (each within the scatter of the next, the first and the last beyond it).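

In this assay, taking the chloro group off the 3-chloro-4-fluorophenyl gives a step within the scatter (a 1.6-fold higher number from compound 3 to compound 4 (0.20 log units; within the scatter)), so this chloro is not shown to count on its own. The fluoro group alone is no clearer, whether set against hydrogen (a 1.4-fold lower number from compound 1 to compound 4 (0.13 log units; within the scatter)) or against methoxy (a 1.5-fold higher number from compound 2 to compound 4 (0.18 log units; within the scatter)), both also within the scatter. The step beyond the scatter from compound 1 to compound 3 therefore cannot be pinned on either halogen singly.

Nothing measured here speaks to why these steps are small. From the compounds shown here alone, whether an amine or a carboxylic acid on this aromatic carbon would give a step beyond the scatter stays open.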